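A few compounds are considered here, and "the series" means these few. Any claim that something is new, unique, unknown or untested is made for them only; others in the source may bear on it.

Of the compounds shown here, three built on one shared core have been tested in an assay on isolated protein for inhibition of Indoleamine 2,3-dioxygenase 1 (Homo sapiens), read by fluorescence, with a stated time of 60 min; on this read-out higher numbers stand for weaker inhibition and lower numbers for stronger inhibition. Compound 1 `CS(=O)(=O)NNc1nonc1/C(=N/O)Nc1ccc(F)c(Br)c1` gives 609 nM. Compound 2 `O=S(=O)(CCNc1nonc1/C(=N/O)Nc1ccc(F)c(Br)c1)N1CCC1` gives 191 nM. Compound 3 `C#CCNS(=O)(=O)CCNc1nonc1/C(=N/O)Nc1ccc(F)c(Br)c1` gives 218 nM, which places compound 3 second highest of the three, close to compound 2 and well apart from compound 1. Compound 4 `NS(=O)(=O)CCONc1nonc1/C(=N/O)Nc1ccc(F)c(Br)c1` differs from compound 3 by 2-sulfamoylethoxy in place of 2-(propargylsulfamoyl)ethyl on a nitrogen on an aromatic ring. The steps bearing on this position are a 3.2-fold lower number from compound 1 to compound 2 (0.50 log units; beyond the scatter) and a 2.8-fold lower number from compound 1 to compound 3 (0.45 log units; beyond the scatter), while a 1.1-fold higher number from compound 2 to compound 3 (0.06 log units; within the scatter) alters only the end of the chain. The chain in compound 4 is joined to the ring nitrogen through a further atom, as in compound 1, which gave 609 nM. A modest weakening is therefore expected for compound 4, a 1.8-fold higher number from compound 3 to compound 4 (0.26 log units; within the scatter). Compound 4 is estimated at 400 nM, within 150 nM to 1100 nM.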

Compound 4, half-maximal inhibitory concentration: 87 nM
Beside the measured number, compound 4's estimate is 4.6-fold (0.66 log units) above it; the whole stated range lies above it.
By their numbers in this assay, from the lowest: compound 4; then compounds 2 and 3 (each within the scatter of the next); then compound 1.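

Compound 4 reverses what compound 1 suggested: a chain joined to the ring nitrogen through a further atom can give the lowest number of the set. The change to 2-sulfamoylethoxy gives a 2.5-fold lower number from compound 3 to compound 4 (0.40 log units; beyond the scatter) and a 2.2-fold lower number from compound 2 to compound 4 (0.34 log units; beyond the scatter), while the step from the shorter group is larger, a 7.0-fold lower number from compound 1 to compound 4 (0.85 log units; beyond the scatter). No measurement shown explains these steps.

From the compounds shown here alone, the change swaps the linking oxygen and the chain end together, so their separate contributions remain open. A 2-sulfamoylethyl group or a longer 3-sulfamoylpropoxy chain on that nitrogen would help to separate them.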